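This account rests on a few compounds, and the source may have more. Where it says the series, first, only, none or still open, it means among the compounds named here.

Measured so far in one assay of metabolic stability:

Compound 1, `CC(=O)Nc1cnc2[nH]c(=O)n([C@H]3CC[C@H](C(C)(C)C)CC3)c(=O)c2c1`, gives 1.4 mL.min-1.g-1.
Compound 2, `CC(=O)Nc1cnc2[nH]c(=O)n([C@H]3CC[C@H](C(C)C)CC3)c(=O)c2c1`, gives 1.4 mL.min-1.g-1.
Compound 3, `CC(C)[C@H]1CC[C@H](n2c(=O)[nH]c3ncc(N)cc3c2=O)CC1`, gives 1.9 mL.min-1.g-1.

All three numbers come from an ADME assay on microsomes from liver (Mus musculus, strain CD1) for metabolic stability, read by HPLC, using NADPH, with a stated time of 30 min, tested at 0.5 uM; on this read-out higher numbers stand for fast clearance and lower numbers for slow clearance. Compound 1 and compound 2 differ in one place: hydrogen in place of methyl on a saturated chain carbon bound to two saturated chain carbons and a saturated ring carbon. That change gives no change at the digits printed from compound 1 to compound 2 (within the scatter). Compound 2 and compound 3 differ by a hydrogen in place of acetyl on a nitrogen on an aromatic ring, and that step reads a 1.4-fold higher number from compound 2 to compound 3 (0.13 log units; within the scatter). How the core of compound 1 and the core of compound 3 differ is not broken down here.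

Compound 4, `CC[C@H]1CC[C@H](n2c(=O)[nH]c3ncc(N)cc3c2=O)CC1`, has not yet been tested. It differs from compound 3 in one place: hydrogen in place of methyl on a saturated chain carbon bound to a saturated chain carbon and a saturated ring carbon. Among the measured compounds shown here, this is the same kind of change as the one from compound 1 to compound 2, but not the same: there the carbon was bound to two saturated chain carbons and a saturated ring carbon, here to a saturated chain carbon and a saturated ring carbon. Since the earlier step gave no change at the digits printed from compound 1 to compound 2 (within the scatter), a similar outcome is expected, namely no change at the digits printed from compound 3 to compound 4 (within the scatter) in this assay. Compound 4 is therefore estimated at 1.9 mL.min-1.g-1, most likely between 1 mL.min-1.g-1 and 3.6 mL.min-1.g-1.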

Compound 4, intrinsic clearance in microsomes: 0.9 mL.min-1.g-1
The estimate for compound 4 lay 2.1-fold (0.32 log units) above the measured number; measured number below the stated range.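

In this assay, taking away one methyl so that isopropyl becomes ethyl gives a 2.1-fold lower number from compound 3 to compound 4 (0.32 log units; beyond the scatter). Set beside the earlier removal of a methyl on the other core, the two steps cannot be told apart: the same change on two cores in this assay, no change at the digits printed (within the scatter) from compound 1 to compound 2 and a 2.1-fold lower number (0.32 log units; beyond the scatter) from compound 3 to compound 4, 2.1-fold (0.32 log units) apart, within the scatter of two such steps. This shows no sign that the change behaves differently from one core to the other, but it does not show that the change carries over unaltered, since one step stays within the scatter, the other lies beyond it, and two steps are too few to support a rule.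

The compounds shown leave open how a longer chain, a carboxylic acid or an amine in place of the ethyl of compound 4 would read in this assay. They also leave open whether the same removal of a methyl would give a similar step on a core that carries neither the acetyl group of compound 2 nor the free nitrogen of compound 3.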